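Acetamido for fluoro on a sulfonyl aryl ring

A few compounds are considered here, and "the series" means these few. Any claim that something is new, unique, unknown or untested is made for them only; others in the source may bear on it.

Of the compounds shown here, three have been measured in a functional assay on SMMC-7721 cells (Homo sapiens) for cytotoxicity, read by MTT assay, with a stated time of 24 h; on this read-out lower numbers stand for stronger inhibition and higher numbers for weaker inhibition. Compound 1, `N#Cc1ccc(/C=C2\CN(S(=O)(=O)c3ccc(F)cc3)C/C(=C\c3ccc(C#N)cc3)C2=O)cc1`, gives 20100 nM in this assay. Compound 2, `CC(=O)Nc1ccc(S(=O)(=O)N2C/C(=C\c3ccc(C#N)cc3)C(=O)/C(=C/c3ccc(C#N)cc3)C2)cc1`, gives 7120 nM. Compound 3, `O=C1/C(=C/c2cccc([N+](=O)[O-])c2)CN(S(=O)(=O)c2ccc(F)cc2)C/C1=C\c1ccccc1F`, gives 7820 nM. The values of compound 2 and compound 3 lie within the scatter of one another, while compound 1 stands apart from both.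

Compound 2 differs from compound 1 in one place: acetamido in place of fluoro on an aromatic carbon. That change brought a 2.8-fold lower number from compound 1 to compound 2 (0.45 log units; beyond the scatter).

Compound 4, `CC(=O)Nc1ccc(S(=O)(=O)N2C/C(=C\c3cccc([N+](=O)[O-])c3)C(=O)/C(=C/c3ccccc3F)C2)cc1`, has not yet been measured. It relates to compound 3 as compound 2 relates to compound 1: acetamido in place of fluoro on an aromatic carbon. The difference between the core of compound 3 and the core of compound 1 is not broken down here, but the change made on each core is the same, at the same place on the same kind of ring.

For the measured compounds named here, a step of about the same size is expected from compound 3 to compound 4 in this assay, because the single earlier instance gave a 2.8-fold lower number from compound 1 to compound 2 (0.45 log units; beyond the scatter). Going by the values given here, with only one earlier example, the step may well be smaller, so the expected step is a 2.2-fold lower number from compound 3 to compound 4 (0.35 log units; beyond the scatter). Compound 4 is accordingly estimated at 3500 nM in this assay, with a range from 1600 nM to 7800 nM.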

Compound 4, half-maximal inhibitory concentration: 10200 nM
The estimate for compound 4 lay 2.9-fold (0.46 log units) below the measured number; the measured number lies above the stated range.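

On the core of compound 3 in this assay, the change from 4-fluorophenyl to 4-acetamidophenyl gave a 1.3-fold higher number from compound 3 to compound 4 (0.12 log units; within the scatter), so the clear drop seen on the core of compound 1 did not recur, and the step here cannot be told from the scatter. Set side by side, the two steps disagree, which shows that the result of this change did not carry from one core to the other in this series: the same change on two cores in this assay, a 2.8-fold lower number (0.45 log units; beyond the scatter) from compound 1 to compound 2 and a 1.3-fold higher number (0.12 log units; within the scatter) from compound 3 to compound 4, 3.7-fold (0.57 log units) apart, beyond the scatter of two such steps

What this does not show is which of the differences between the cores matters, whether the two nitrile groups of the core of compound 1 or the nitro and fluoro groups of the core of compound 3, and two pairs of compounds give no rule for any other core in the series.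

The compounds shown leave open what the same change would do on a core that mixes these groups, for example one nitrile group together with one nitro group, which could help locate the source of the disagreement. They also leave open how an amine or a carboxylic acid in place of the acetamido group on the sulfonyl aryl ring would behave on either core.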